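Morpholine to Piperidine on the Amide: An Estimated Step

The source may report more compounds than this note shows. Statements on the series, on what has been measured and on what is new or still open speak of the compounds shown alone.

Of the compounds shown here, two have so far been tested in a functional assay on MDA-MB-231 cells (Homo sapiens) for inhibition, read by MTT assay, with a stated time of 48 h; a lower number here means a stronger inhibitor, a higher number a weaker inhibitor. Compound 1 `COc1cc(-c2nc3cc(/C=C4\SC(=O)N(CC(=O)N5CCOCC5)C4=O)ccc3[nH]2)cc(OC)c1OC` gives 14900 nM. Compound 2 `COc1cc(OC)c(-c2nc3cc(/C=C4\SC(=O)N(CC(=O)N5CCOCC5)C4=O)ccc3[nH]2)cc1OC` gives 21300 nM. Going by the values given here, the only measured step, a 1.4-fold higher number from compound 1 to compound 2 (0.16 log units; within the scatter), concerns the trimethoxyphenyl group and is within the scatter, so compound 2 and compound 1 cannot be told apart on these numbers; compound 2 simply holds one of two values that sit close together.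

Compound 3 `COc1cc(OC)c(-c2nc3cc(/C=C4\SC(=O)N(CC(=O)N5CCCCC5)C4=O)ccc3[nH]2)cc1OC` differs from compound 2 in one place: piperidin-1-yl in place of morpholin-4-yl on a carbonyl carbon. Among the compounds with values here, no measured step touches this part of the molecule; the one step recorded changes a different group and was itself within the scatter. There is therefore nothing in the data to suggest a shift in this assay beyond the scatter in either direction, and the sensible expectation is that compound 3 stays near compound 2.

Compound 3 is accordingly expected to give about 20000 nM, with a range from 7000 nM to 60000 nM. The expected step of a 1.1-fold lower number from compound 2 to compound 3 (0.03 log units; within the scatter) is estimated to lie within the scatter.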

Compound 3, half-maximal inhibitory concentration: > 50000 nM
Compound 3: no number, only a limit; the forecaster's own chance of this, stated with the estimate: 10%; middle value at least 2.5-fold (0.39 log units) away from the limit.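

In this assay, going by these compounds alone, the group on the carbonyl carbon turns out to matter: piperidin-1-yl in place of morpholin-4-yl gives an at least 2.3-fold higher number from compound 2 to compound 3 (0.37 log units; beyond the scatter), whereas the one earlier step, on the trimethoxyphenyl group, stayed within the scatter. The reading for compound 3 is a limit of the assay, not a number: the limit of > 50000 nM in this assay, at which 1 of the 3 values shown sits. Both groups are six-membered non-aromatic rings with 6 heavy atoms, but morpholin-4-yl holds 1 oxygen and 1 hydrogen-bond acceptor and piperidin-1-yl holds neither, so this pair shows that a modest change in the ring can carry the number beyond the scatter, without showing why.

The compounds shown leave open what number compound 3 truly has, and whether the same change would act alike on the core of compound 1, with its 3,4,5-trimethoxyphenyl group. They also leave open whether the ring oxygen itself is what counts: a piperazin-1-yl group or an open-chain dimethylamino group on the same carbonyl carbon would bear on that question.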